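A fluoro swapped for hydrogen on compound 2

This account rests on a few compounds, and the source may have more. Where it says the series, first, only, none or still open, it means among the compounds named here.

Compound 1 (`O=C(Nc1cc(C(F)(F)F)cc(C(F)(F)F)c1)c1ccc(Br)cc1O`) gives 270 nM
Compound 2 (`O=C(Nc1cc(C(F)(F)F)cc(C(F)(F)F)c1)c1cc(Br)c(F)cc1O`) gives 250 nM

Both numbers come from a functional assay on HL-60 cells (Homo sapiens) for cytotoxicity, read by luminescence and CellTiter-Glo, with a stated time of 3 days; on this read-out higher numbers stand for weaker inhibition and lower numbers for stronger inhibition. In this assay compound 2 gives 250 nM and stands level with compound 1, since the gap between the two lies within the usual scatter of repeated measurements. Compound 3 (`O=C(Nc1cc(C(F)(F)F)cc(C(F)(F)F)c1)c1cc(Br)ccc1O`) has not been measured yet. It is compound 2 with hydrogen in place of fluoro on an aromatic carbon. Going by the values given here, the two measured compounds differ in more than one place, so no measured step shows directly what this swap does. One hint is available: compound 1 also carries no fluoro and gives 270 nM in the same test, level with compound 2. Among the compounds with values here, this is thin evidence, resting on only two compounds. A step of a 1.0-fold lower number from compound 2 to compound 3 (0.02 log units; within the scatter) is therefore expected to stay within the scatter in this assay, with no clear direction. In this assay the estimate for compound 3 is 240 nM (range 110 nM to 550 nM).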

Compound 3, half-maximal inhibitory concentration: 290 nM
For compound 3 the middle estimate is 1.2-fold (0.08 log units) below the measured one; measured number inside the range.
By their numbers in this assay, from the lowest: compounds 2, 1 and 3 (each within the scatter of the next).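

On the shared core, the fluoro that sits ortho to a bromo group and meta to a hydroxy group can give way to hydrogen in this assay with a 1.2-fold higher number from compound 2 to compound 3 (0.06 log units; within the scatter), so this direct comparison shows no measurable difference between the two atoms at this position. A second comparison concerns the bromo group: having 5-bromo-2-hydroxyphenyl in place of 4-bromo-2-hydroxyphenyl gives a 1.1-fold higher number from compound 1 to compound 3 (0.03 log units; within the scatter), so these two arrangements also stand level in this test. Nothing measured here explains why either change leaves the read-out level.

As far as these compounds go, with only fluoro and hydrogen compared at this position, it remains open whether a methoxy group, an amine or a carboxylic acid there would stay level with compound 2 or move clearly away from it. All of these numbers also come from a single test on one cell line, so they cannot tell whether compound 2 and compound 3 would stay level in other cells or in a different kind of test.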